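The source may hold more compounds than are shown below. What is called first, only, known or untested is meant among the compounds shown, and "the series" means these compounds.

Series notes. Compound 1 `OCc1cc(Br)c(O)c(O)c1Br` gives 15000 nM in a functional assay on DLD-1 cells (Homo sapiens) for cytotoxicity, read by MTT assay, with a stated time of 96 h; a lower number here means a stronger inhibitor, a higher number a weaker inhibitor. Compound 2 `CCOCc1cc(O)c(O)c(Br)c1` gives 35100 nM in this assay. Compound 3 `COCc1cc(Br)c(O)c(O)c1Br` gives 7270 nM in this assay, the lowest of the three numbers; compound 1 stands nearest to it and compound 2 furthest. Compound 4 `CCOCc1cc(Br)c(O)c(O)c1Br` has not yet been measured in this assay. The change from compound 3 is methyl in place of hydrogen on a saturated chain carbon bound to an oxygen on a saturated carbon. A single measured step bears on it: a 2.1-fold lower number from compound 1 to compound 3 (0.31 log units; beyond the scatter), which grew the same chain at the oxygen on a saturated carbon. For the measured compounds named here, compound 2 also carries the ethoxymethyl group but lacks a bromine that compound 3 has, and no single-point step links it to compound 3 or compound 4; its number simply stands higher than that of compound 3. Extending the chain by a further carbon is expected to lower the number only modestly, if at all beyond the scatter, so the estimated step is a 1.3-fold lower number from compound 3 to compound 4 (0.12 log units; within the scatter). For compound 4 the expected value in this assay is 5500 nM, with a range from 2500 nM to 12000 nM.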

Compound 4, half-maximal inhibitory concentration: 7150 nM
Compound 4: middle estimate off by 1.3-fold (0.11 log units), on the low side; low and high end bracket the measured number.
By their numbers in this assay, from the lowest: compounds 4 and 3 (each within the scatter of the next); then compound 1; then compound 2.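

In this assay, the added carbon on this chain shows no readable effect: methoxymethyl to ethoxymethyl gives a 1.0-fold lower number from compound 3 to compound 4 (0.01 log units; within the scatter). Ethyl in place of hydrogen on the oxygen gives a 2.1-fold lower number from compound 1 to compound 4 (0.32 log units; beyond the scatter), so the step from compound 1 is also seen with a group other than methyl, though the two capped compounds cannot be told apart. The series also gains its first single-place reading of the bromo group, a 4.9-fold lower number from compound 2 to compound 4 (0.69 log units; beyond the scatter), which links compound 2 to the rest of the series.

As far as these compounds go, it remains open whether a longer chain such as butoxymethyl, or an aminomethyl group at this place, would keep the number level with compound 3 and compound 4. No measurement at hand accounts for any of these steps.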